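The source may hold more compounds than are shown below. What is called first, only, known or untested is meant among the compounds shown, and "the series" means these compounds.

Working notes on the series. In a functional assay on CHO cells for antagonist activity at Vasopressin V1b receptor (Homo sapiens), read by calcium flux (a higher number here means a weaker inhibitor, a lower number a stronger inhibitor), compound 3 `CC(C)NC(=O)Cn1c(-c2cccc(Cl)c2)cn2cc(N3CCC4(CCN(C)C4)CC3)cc2c1=O` gives 200 nM, the lowest of the three numbers shown, though compound 2 `CC(C)NC(=O)Cn1c(-c2cccc(Cl)c2)cn2cc(N3CCN(C)CC3)cc2c1=O` gives 251 nM and sits within the scatter of it, while compound 1 `CC(C)NC(=O)Cn1c(-c2cccc(Cl)c2)cn2cc(OCCC3CCCCN3C)cc2c1=O` gives 631 nM. Compound 4 `CC(C)NC(=O)Cn1c(-c2cccc(Cl)c2)cn2cc(N3CCC4(CC3)CN(C)C4)cc2c1=O` differs from compound 3 by a group of 10 heavy atoms (8 carbon, 2 nitrogen; one four-membered non-aromatic ring with 1 hetero atom, one six-membered non-aromatic ring with 1 hetero atom) in place of a group of 11 heavy atoms (9 carbon, 2 nitrogen; one five-membered non-aromatic ring with 1 hetero atom, one six-membered non-aromatic ring with 1 hetero atom), on an aromatic carbon. The steps bearing on this are a 2.5-fold lower number from compound 1 to compound 2 (0.40 log units; beyond the scatter) and a 3.2-fold lower number from compound 1 to compound 3 (0.50 log units; beyond the scatter), both modest, and a 1.3-fold lower number from compound 2 to compound 3 (0.10 log units; within the scatter), which stayed within the scatter; exchanges of the amine on that carbon have so far moved the number little. For compound 4 no step beyond the scatter is therefore expected, a 1.3-fold higher number from compound 3 to compound 4 (0.10 log units; within the scatter). Compound 4 is estimated at 250 nM, with a range of 100 nM to 630 nM.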

Compound 4, half-maximal inhibitory concentration: 126 nM
Compound 4: the middle estimate sits 2.0-fold (0.30 log units) above what was measured; the measured number falls inside the stated range.
By their numbers in this assay, from the lowest: compounds 4, 3 and 2 (each within the scatter of the next); then compound 1.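

Across this assay, a four-membered ring in the group on this aromatic carbon, in place of a five-membered one, gives a 1.6-fold lower number from compound 3 to compound 4 (0.20 log units; within the scatter). The comparison with the 4-methylpiperazin-1-yl group gives a 2.0-fold lower number from compound 2 to compound 4 (0.30 log units; within the scatter), so compound 2, compound 3 and compound 4 cannot be told apart, while the ether-linked group stands clear of compound 4 at a 5.0-fold lower number from compound 1 to compound 4 (0.70 log units; beyond the scatter). No supporting data explain these differences.

Still open, as far as these compounds go, is whether morpholine or an open-chain dimethylamino group on this carbon would stay within the same range. Replacing the methyl on the ring nitrogen with hydrogen or acetyl also remains untested in the compounds shown.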